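Benzyl in place of isopropyl on the core nitrogen

The compounds below may be only part of what the source reports. "The series", "measured", "known", "first", "only" and "open" are said of these compounds alone.

In a functional assay on NCI-H460 cells (Homo sapiens) for antiproliferative activity, read by CCK-8 assay, with a stated time of 72 h, tested at 2 uM (a lower number here means a weaker effect, a higher number a stronger effect of the compound at the concentration tested), compound 3 `CC(C)n1cnc2c(NCc3ccc(C(=O)Nc4ccccc4N)cc3)nc(Cl)nc21` gives 54.2%, the highest of the three numbers to hand. Compound 1 `CCC(C)n1cnc2c(NCc3ccc(C(=O)Nc4ccccc4N)cc3)nc(Cl)nc21` gives 47.3%, and the step of a number 6.9 percentage points higher from compound 1 to compound 3 (within the scatter) lies within the scatter, so compound 3 and compound 1 cannot be told apart. Compound 2 `CCCCn1cnc2c(NCc3ccc(C(=O)Nc4ccccc4N)cc3)nc(Cl)nc21` gives 19.7%, and the step of a number 34.5 percentage points higher from compound 2 to compound 3 (beyond the scatter) lies beyond the scatter. Compound 4 `Nc1ccccc1NC(=O)c1ccc(CNc2nc(Cl)nc3c2ncn3Cc2ccccc2)cc1` is not yet measured in this assay; it differs from compound 3 in one place: benzyl in place of isopropyl on an aromatic nitrogen. Among the measured compounds shown here, two measured steps bear on this change, both at the same aromatic nitrogen: a number 27.6 percentage points lower from compound 1 to compound 2 (beyond the scatter) and a number 34.5 percentage points higher from compound 2 to compound 3 (beyond the scatter). In both, the butyl group went with the lowest number and the isopropyl group with the highest. Benzyl is a larger group than butyl and carries an aromatic ring, for which no measured step exists in this series. A downward step is therefore expected, a number 24.2 percentage points lower from compound 3 to compound 4 (beyond the scatter), with wide uncertainty. Compound 4 is estimated at 30%, expected to fall between 10% and 55%.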

Compound 4, a percentage reported as inhibition, at one concentration (the size of the read-out at that concentration, not a potency): 43.8%
Beside the measured number, compound 4's estimate is 13.8 percentage points below it; measured number inside the range.
By their numbers in this assay, from the lowest: compound 2; then compounds 4, 1 and 3 (each within the scatter of the next, the first and the last beyond it).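

Benzyl, the only group here with a six-membered aromatic ring, is tolerated on this aromatic nitrogen far better than the butyl group suggested: the step is a number 24.1 percentage points higher from compound 2 to compound 4 (beyond the scatter), while a number 10.4 percentage points lower from compound 3 to compound 4 (beyond the scatter) is only a modest loss and a number 3.5 percentage points lower from compound 1 to compound 4 (within the scatter) leaves benzyl and sec-butyl indistinguishable. Among the four groups, compound 2 alone has steps beyond the scatter to every other compound, so the 7 heavy atoms of benzyl do not bring the number down to the butyl level, and substituent size alone does not order this position. No evidence is available to explain these differences.

As far as these compounds go, it remains open whether a phenethyl, a cyclohexyl or a methoxy-substituted benzyl group would track with benzyl or with butyl. A straight propyl or pentyl chain would show whether the low number is peculiar to butyl.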